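Chloro in Place of Trifluoromethyl on the Benzylidene Arm

The source may report more compounds than this note shows. Statements on the series, on what has been measured and on what is new or still open speak of the compounds shown alone.

Measured compounds:
compound 1 `C=CCn1c(=O)/c(=C\c2cccc(C)c2)[nH]c(=O)/c1=C\c1ccccc1OC` gives 20700 nM in a functional assay on MCF7 cells (Homo sapiens) for cytotoxicity, read by CCK-8 assay, with a stated time of 72 h; a higher number here means a weaker inhibitor, a lower number a stronger inhibitor
compound 2 `C=CCn1c(=O)/c(=C\c2ccccc2F)[nH]c(=O)/c1=C\c1ccccc1OC` gives 23000 nM in this assay
compound 3 `C=CCn1c(=O)/c(=C\c2ccccc2C(F)(F)F)[nH]c(=O)/c1=C\c1ccccc1OC` gives 6500 nM in this assay

Compound 3 stands lowest of the three numbers, with a 3.2-fold lower number from compound 1 to compound 3 (0.50 log units; beyond the scatter) and a 3.5-fold lower number from compound 2 to compound 3 (0.55 log units; beyond the scatter) both beyond the scatter, while a 1.1-fold higher number from compound 1 to compound 2 (0.05 log units; within the scatter) stays within it. The next compound, compound 4 `C=CCn1c(=O)/c(=C\c2ccccc2Cl)[nH]c(=O)/c1=C\c1ccccc1OC`, keeps the core and differs from compound 3 in one spot: chloro in place of trifluoromethyl on an aromatic carbon.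

The step that bears most directly on this change is the one from fluoro to trifluoromethyl, a 3.5-fold lower number from compound 2 to compound 3 (0.55 log units; beyond the scatter), a modest drop in the number. Chloro brings a single heavy atom to the same aromatic carbon, as fluoro did, so part of that drop may be given back. Compound 4 is therefore expected to give a somewhat higher number than compound 3, a 1.7-fold higher number from compound 3 to compound 4 (0.23 log units; within the scatter), though not as high as compound 2. The estimate for compound 4 in this assay is 11000 nM, with a range from 5500 nM to 22000 nM.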

Compound 4, half-maximal inhibitory concentration: 4700 nM
Compound 4: the middle estimate sits 2.3-fold (0.37 log units) above what was measured; the whole stated range lies above it.
By their numbers in this assay, from the lowest: compounds 4 and 3 (each within the scatter of the next); then compounds 1 and 2 (each within the scatter of the next).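

At this aromatic carbon, a 1.4-fold lower number from compound 3 to compound 4 (0.14 log units; within the scatter) stays within the scatter in this assay, so chloro and trifluoromethyl cannot be told apart here, although one has a single heavy atom and the other has four. Fluoro and chloro each bring a single heavy atom, yet a 4.9-fold lower number from compound 2 to compound 4 (0.69 log units; beyond the scatter) lies beyond the scatter, so the heavy-atom count alone does not follow the number at this carbon. The 2-chlorophenyl arm also separates from the 3-methylphenyl arm, with a 4.4-fold lower number from compound 1 to compound 4 (0.64 log units; beyond the scatter) beyond the scatter as well.

Nothing shown here explains why fluoro behaves differently from chloro and trifluoromethyl. On these data alone, whether bromo or an amine on this same aromatic carbon would give a number close to those of compound 3 and compound 4 remains open.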